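Quinoline ether amides: solubility notes toward compound 3

The compounds below may be only part of what the source reports. "The series", "measured", "known", "first", "only" and "open" are said of these compounds alone.

Measured so far in a physicochemical assay for solubility, in phosphate buffer, measured as kinetic solubility, with a stated time of 1 h, at pH 7.4; on this read-out lower numbers stand for lower solubility and higher numbers for higher solubility:
- compound 1 `COc1ccc2nc(C)cc(OCC(=O)NCc3cc(C)cc(C)c3)c2c1` gives 92000 nM
- compound 2 `COc1ccc2nc(C)cc(OCC(=O)Nc3cc(F)cc(F)c3)c2c1` gives 13000 nM

Compound 2 holds the lowest of the two numbers in this assay; its nearest neighbour, compound 1, stands higher by the step of a 7.1-fold lower number from compound 1 to compound 2 (0.85 log units; beyond the scatter). That single step is the only one available, and it swaps one amide substituent for another in the same place as the change now considered.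

Compound 3 `COc1ccc2nc(C)cc(OCC(=O)Nc3ccncn3)c2c1` differs from compound 2 in one place: pyrimidin-4-yl in place of 3,5-difluorophenyl on an amide-type nitrogen. Among the measured compounds shown here, no measured pair carries a pyrimidin-4-yl group on the amide-type nitrogen, so the step from compound 1 to compound 2 bears on the present change only in that it shows the amide substituent can move this assay by a modest amount.

For compound 3 a modest rise in this assay is expected, amounting to the step of a 2.7-fold higher number from compound 2 to compound 3 (0.43 log units; beyond the scatter), with wide uncertainty. The estimate for compound 3 in this assay is 35000 nM, within a range of 10000 nM to 120000 nM.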

Compound 3, solubility: 27500 nM
The estimate for compound 3 lay 1.3-fold (0.10 log units) above the measured number, and the stated range covers the measured number.
By their numbers in this assay, from the lowest: compound 2; then compound 3; then compound 1.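

In this assay, the amide-type nitrogen now has three substituents to compare, and pyrimidin-4-yl, which brings 2 hydrogen-bond acceptors where 3,5-difluorophenyl has 0, gives a 2.1-fold higher number from compound 2 to compound 3 (0.33 log units; beyond the scatter) as a modest step beyond the scatter. Measured against 3,5-dimethylbenzyl at the same place, the same group gives a 3.3-fold lower number from compound 1 to compound 3 (0.52 log units; beyond the scatter), so compound 3 sits between compound 2 and compound 1 and this position shows a graded order on the shared core rather than a single step. No supporting measurement is available to explain either step.

In this pair the two ring nitrogens enter and the two fluorines leave together. The compounds shown do not separate these two changes, and an unsubstituted phenyl or a pyridin-4-yl group would be needed to separate them. Also open, going by these compounds, is whether a substituent of another kind at this nitrogen, such as a chain ending in a carboxylic acid or an amine, would extend the order beyond the three numbers now in hand.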